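Swapping a Methoxyphenyl for an Iodophenyl Group

The source may report more compounds than this note shows. Statements on the series, on what has been measured and on what is new or still open speak of the compounds shown alone.

Of the compounds shown here, three built on one shared core have been tested in a functional assay on cells (Splenocyte, Mus musculus, strain BALB/c) for inhibition, read by scintillation counting and thymidine incorporation, with a stated time of 72 h; on this read-out higher numbers stand for weaker inhibition and lower numbers for stronger inhibition. Compound 1 `CC(/C=N/Nc1ccc([N+](=O)[O-])cc1)=N\NC(=O)c1ccccc1Cl` carries a 2-chlorophenyl group on the carbonyl carbon. In this assay compound 1 reaches only the limit > 12000 nM, which is not a number. Compound 2 `CC(/C=N/Nc1ccc([N+](=O)[O-])cc1)=N\NC(=O)c1ccc([N+](=O)[O-])cc1` carries a 4-nitrophenyl group in that place, and in this assay compound 2 gives 980 nM, a change of an at least 12-fold lower number from compound 1 to compound 2 (1.08 log units; beyond the scatter). Compound 3 `COc1ccc(C(=O)N/N=C(C)/C=N/Nc2ccc([N+](=O)[O-])cc2)cc1` carries a 4-methoxyphenyl group. In this assay compound 3 sits at the limit > 12000 nM, again not a number. Against compound 2 this is an at least 12-fold higher number from compound 2 to compound 3 (1.08 log units; beyond the scatter), while the change is a step that the two limits leave unreadable from compound 1 to compound 3 because of the limit of > 12000 nM in this assay, at which 2 of the 3 values shown sit.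

Compound 4 `CC(/C=N/Nc1ccc([N+](=O)[O-])cc1)=N\NC(=O)c1ccccc1I` has not yet been measured. The change is 2-iodophenyl in place of 4-methoxyphenyl on a carbonyl carbon, which makes compound 4 resemble compound 1, whose 2-chlorophenyl group differs from it only in the halogen. With compound 1 at its limit, compound 4 is expected to stay at the limit too, so the step that the limit leaves unreadable from compound 3 to compound 4 is expected to be none beyond the scatter. Compound 4 is therefore estimated at 15000 nM, in a range from 6000 nM to 40000 nM.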

Compound 4, half-maximal inhibitory concentration: 2980 nM
For compound 4 the middle estimate is 5.0-fold (0.70 log units) above the measured one; the measured number lies below the stated range.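

In this assay, changing only the halogen matters: iodo in place of chloro gives an at least 4.0-fold lower number from compound 1 to compound 4 (0.60 log units; beyond the scatter), so this carbonyl substituent is not closed off to halogen-bearing phenyl groups. The 2-iodophenyl group also beats the 4-methoxyphenyl group, with an at least 4.0-fold lower number from compound 3 to compound 4 (0.60 log units; beyond the scatter), yet it does not match the 4-nitrophenyl group, with a 3.0-fold higher number from compound 2 to compound 4 (0.48 log units; beyond the scatter), leaving compound 2 with the lowest number of the four. The first and second of these steps give only a minimum size because compound 1 and compound 3 each rest on a limit, not a number: the limit of > 12000 nM in this assay, at which 2 of the 4 values shown sit.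

The compounds shown leave open whether the iodo group would act the same way as a 4-iodophenyl group. They also leave open how a 2-nitrophenyl or a 4-aminophenyl group would behave on this carbonyl carbon.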